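A Nitro Group Tried in Place of Phenyl

The compounds below may be only part of what the source reports. "The series", "measured", "known", "first", "only" and "open" are said of these compounds alone.

Compound 1 `O=C(Cc1cccnc1)c1cc2cc(-c3ccccc3)ccc2[nH]1` is the starting point. In an assay on isolated protein for inhibition of Indoleamine 2,3-dioxygenase 1 (Homo sapiens), read by spectrophotometry (a higher number here means a weaker inhibitor, a lower number a stronger inhibitor), compound 1 gives 96000 nM. Compound 2 `O=C(Cc1cccnc1)c1cc2c(O)cccc2[nH]1` gives 83000 nM in this assay, and the gap between these two numbers lies within the usual scatter, so neither compound can be called the stronger inhibitor. Compound 3 `OC(Cc1cccnc1)c1cc2ccccc2[nH]1` is reported in this assay as "not active" (no number reported), with no number attached. Compound 4 `O=C(Cc1cccnc1)c1cc2cc([N+](=O)[O-])ccc2[nH]1` differs from compound 1 in one place: nitro in place of phenyl on an aromatic carbon. Within the data shown here, no measured pair shows a comparable change, so the two weak values of compounds 1 and 2 are the only guide. The step the author expects is a 1.1-fold lower number from compound 1 to compound 4 (0.03 log units; within the scatter), in either direction not beyond the scatter. Compound 4 is therefore expected at 90000 nM, within a range from 25000 nM to 300000 nM.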

Compound 4, half-maximal inhibitory concentration: "not active" (no number reported)
The entry for compound 4 holds no number, so the estimate cannot be set against anything.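

Among these compounds, compound 4 is reported as "not active" with no number attached, so no step from compound 1 to compound 4 can be read in this assay. The compounds shown leave open how large the change from phenyl to nitro is. No measured evidence bears on this result.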